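The source may hold more compounds than are shown below. What is called first, only, known or untested is meant among the compounds shown, and "the series" means these compounds.

Of the compounds shown here, two built on one shared core have been measured in a functional assay on MCF7 cells (Homo sapiens) for antiproliferative activity, read by sulforhodamine B assay, with a stated time of 48 h; a lower number here means a stronger inhibitor, a higher number a weaker inhibitor. Compound 1 `CCCC(=O)Nc1ccc(S(=O)(=O)Oc2ccccc2I)cc1` gives 9700 nM in this assay, and compound 2 `CC(C)(C)C(=O)Nc1ccc(S(=O)(=O)Oc2ccccc2I)cc1` gives 6600 nM. Within the data shown here, the single step between them, a 1.5-fold lower number from compound 1 to compound 2 (0.17 log units; within the scatter), falls within the scatter, so compound 2 holds the lower of the two numbers without being separated from compound 1 by any real margin. The next compound, compound 3 `O=C(CCCCl)Nc1ccc(S(=O)(=O)Oc2ccccc2I)cc1`, differs from compound 2 by 3-chloropropyl in place of tert-butyl on a carbonyl carbon. Among the measured compounds shown here, the only measured step that bears on this change is a 1.5-fold lower number from compound 1 to compound 2 (0.17 log units; within the scatter), which also exchanged one group on that carbonyl carbon for another and stayed within the scatter. On that basis the expected step is a 1.2-fold higher number from compound 2 to compound 3 (0.08 log units; within the scatter), meaning no shift beyond the scatter in this assay. Compound 3 is therefore estimated at 8000 nM, with a range from 3000 nM to 20000 nM.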

Compound 3, half-maximal inhibitory concentration: 6300 nM
Compound 3: the middle estimate sits 1.3-fold (0.10 log units) above what was measured, and the stated range covers the measured number.
By their numbers in this assay, from the lowest: compounds 3, 2 and 1 (each within the scatter of the next).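

In this assay, putting 3-chloropropyl in place of tert-butyl on the carbonyl carbon gives a 1.0-fold lower number from compound 2 to compound 3 (0.02 log units; within the scatter), so a third open-chain group at this position brings no shift beyond the scatter. The chlorine also allows a second comparison: chloro in place of hydrogen on a saturated chain carbon, three bonds along the chain from a carbonyl carbon, gives a 1.5-fold lower number from compound 1 to compound 3 (0.19 log units; within the scatter), which also stays within the scatter. No measurement shown here offers an explanation for these close numbers.

From the compounds shown here alone, all three groups at this position are open-chain, carry no net charge and have no ring, so it remains open whether an amine, a carboxylic acid or a phenyl ring here would move the number beyond the scatter. Going by these compounds, whether a much longer chain would do so also remains open.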